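Side-chain swaps and clearance in the nitrile series

The source may report more compounds than this note shows. Statements on the series, on what has been measured and on what is new or still open speak of the compounds shown alone.

Measured so far in an in vitro ADME assay on microsomes from liver (Homo sapiens) for metabolic stability, using NADPH; on this read-out higher numbers stand for fast clearance and lower numbers for slow clearance
- compound 1 `CC(C)(O)CCNC(=O)c1cc2cc(C#N)ccc2n1Cc1cccc(OC(F)(F)F)c1` gives 9 mL.min-1.g-1
- compound 2 `N#Cc1ccc2c(c1)cc(C(=O)NCCC(O)C(F)(F)F)n2Cc1cccc(OC(F)(F)F)c1` gives 59 mL.min-1.g-1
- compound 3 `N#Cc1ccc2c(c1)cc(C(=O)NCCC(O)(C(F)(F)F)C(F)(F)F)n2Cc1cccc(OC(F)(F)F)c1` gives 20 mL.min-1.g-1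

Compound 3 lies in the middle of the three, as shown by a 2.2-fold higher number from compound 1 to compound 3 (0.35 log units; beyond the scatter) and a 3.0-fold lower number from compound 2 to compound 3 (0.47 log units; beyond the scatter). Moving on to compound 4 `CC(O)C1(CNC(=O)c2cc3cc(C#N)ccc3n2Cc2cccc(OC(F)(F)F)c2)CCCC1` brings (a group of 8 heavy atoms (7 carbon, 1 oxygen; one five-membered non-aromatic ring of carbon only) in place of a group of 11 heavy atoms (4 carbon, 1 oxygen, 6 fluorine; no ring), on a saturated chain carbon bound to an amide-type nitrogen). The nearest evidence is side-chain change elsewhere in the series, and a 6.6-fold higher number from compound 1 to compound 2 (0.82 log units; beyond the scatter) is the largest step, still modest. Among the measured compounds shown here, no measured compound carries the new ring, so these steps bear only indirectly. Compound 4 shares a secondary alcohol with compound 2 at 59 mL.min-1.g-1, which points to a modest rise in this assay. The expected change is a 2.3-fold higher number from compound 3 to compound 4 (0.35 log units; beyond the scatter). The estimate for compound 4 is 45 mL.min-1.g-1, with an expected range of 18 mL.min-1.g-1 to 110 mL.min-1.g-1.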

Compound 4, intrinsic clearance in microsomes: 505 mL.min-1.g-1
Estimate against measurement, compound 4: 11-fold (1.05 log units) below; measured number above the stated range.
By their numbers in this assay, from the lowest: compound 1; then compound 3; then compound 2; then compound 4.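

At this position the group with the five-membered non-aromatic carbon ring brings a 25-fold higher number from compound 3 to compound 4 (1.40 log units; beyond the scatter) along with an 8.6-fold higher number from compound 2 to compound 4 (0.93 log units; beyond the scatter) and a 56-fold higher number from compound 1 to compound 4 (1.75 log units; beyond the scatter) in this assay and sets the top of the series. The side chain here can therefore move this read-out much further than the earlier swaps showed, and lacking fluorine does not by itself keep the number low, since compound 1 also lacks fluorine yet stays lowest. No measurement at hand accounts for the rise.

Still open, as far as these compounds go, is whether the ring or the secondary alcohol drives the rise. Also open, from the compounds shown here alone, is how an amine or a carboxylic acid would read at this position.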